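The source may report more compounds than this note shows. Statements on the series, on what has been measured and on what is new or still open speak of the compounds shown alone.

Compound 1 `O=C(CCCCCCCCCCc1ccccc1)N1CCCCC1`: > 100000 nM
Compound 2 `N#Cc1ccc(CCCCCCCCC(=O)N2CCCCC2)cc1`: > 100000 nM
Compound 3 `O=C(CCCCCCCCc1ccccc1F)N1CCCCC1`: 98900 nM

All three were tested in a functional assay on PANC-1 cells (Homo sapiens) for cytotoxicity, read by WST assay, with a stated time of 24 h; a higher number here means a weaker inhibitor, a lower number a stronger inhibitor. The entry for compound 1 is a limit of the assay, not a number. The entry for compound 2 is also a limit. Compound 3 alone gives a true number, and so it is the only fixed point in the series. The series is crowded against (the limit of > 100000 nM in this assay, at which 2 of the 3 values shown sit).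

Compound 4 `O=C(CCCCCCCCc1cccc(F)c1)N1CCCCC1` carries 3-fluorophenyl in place of 2-fluorophenyl on a saturated chain carbon, eight bonds along the chain from a carbonyl carbon. Two measured steps change the group at this place on the chain: a number no higher from compound 1 to compound 3 (the limit leaves the size open) and a number no higher from compound 2 to compound 3 (the limit leaves the size open). Limits leave the size of both open, so neither points to a real change. The expected result is a 1.0-fold lower number from compound 3 to compound 4 (0.02 log units; within the scatter), which would be no step beyond the usual scatter. For compound 4 the estimated value is 95000 nM, with an expected range of 50000 nM to 150000 nM.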

Compound 4, half-maximal inhibitory concentration: > 100000 nM
Compound 4: only a limit was reported; the forecaster's own chance of this, stated with the estimate: 50%; middle value at least 1.0-fold (0.02 log units) from the limit.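

In this assay, putting 3-fluorophenyl in place of 2-fluorophenyl on this saturated chain carbon gives a number no lower from compound 3 to compound 4 (the limit leaves the size open). The entry for compound 4 is a limit, not a number, so the real size of this change stays hidden, and the steps to compound 4 from compound 1 and compound 2 cannot be read. Compound 3 remains the only true number, and the series is now more crowded against one edge of the assay: the limit of > 100000 nM in this assay, at which 3 of the 4 values shown sit.

As far as these compounds go, how far compound 4 truly lies from compound 3 remains open. So does whether 4-fluorophenyl, or a phenyl ring carrying an amine or a carboxylic acid, would give a clearly lower number at this place.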